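A few compounds are considered here, and "the series" means these few. Any claim that something is new, unique, unknown or untested is made for them only; others in the source may bear on it.

Working notes on the series. Compound 1 `COc1ccc(NC(=O)C2(C(=O)Nc3ccc(Nc4ncc5cc(C(=O)N(C)C)n(C6CCCC6)c5n4)cc3)CC2)cc1` in a functional assay on A549 cells (Homo sapiens) for inhibition, read by CCK-8 assay, with a stated time of 72 h, tested at 10 uM (a higher number here means more inhibition of growth at the concentration tested, a lower number less inhibition of growth), gives 78.5%, the lowest of the three measured values. Compound 2 `CN(C)C(=O)c1cc2cnc(Nc3ccc(NC(=O)C4(C(=O)Nc5cccc(Cl)c5)CC4)cc3)nc2n1C1CCCC1` gives 90.7% and compound 3 `Cc1ccc(NC(=O)C2(C(=O)Nc3ccc(Nc4ncc5cc(C(=O)N(C)C)n(C6CCCC6)c5n4)cc3)CC2)cc1` gives 90.6%. Both departures from compound 1 were modest rises beyond the scatter, a number 12.2 percentage points higher from compound 1 to compound 2 (beyond the scatter) and a number 12.1 percentage points higher from compound 1 to compound 3 (beyond the scatter), while a number 0.1 percentage points lower from compound 2 to compound 3 (within the scatter) lies within the scatter. Compound 4 `CN(C)C(=O)c1cc2cnc(Nc3ccc(NC(=O)C4(C(=O)Nc5ccc(C(F)(F)F)cc5)CC4)cc3)nc2n1C1CCCC1` differs from compound 1 by trifluoromethyl in place of methoxy on an aromatic carbon. Both measured steps that bear on this change raised the number by a similar modest amount, so for compound 4 a modest rise beyond the scatter in this assay is expected, because of a number 12.2 percentage points higher from compound 1 to compound 2 (beyond the scatter) and a number 12.1 percentage points higher from compound 1 to compound 3 (beyond the scatter). For compound 4 the estimate is 88%, with a range of 76% to 96%. That estimate means an expected step of a number 9.5 percentage points higher from compound 1 to compound 4 (within the scatter).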

Compound 4, percent growth inhibition at one concentration: 87.9%
The estimate for compound 4 lay 0.1 percentage points above the measured number; the range from low to high includes it.
By their numbers in this assay, from the lowest: compounds 1, 4, 3 and 2 (each within the scatter of the next, the first and the last beyond it).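

In this assay, trifluoromethyl in place of methoxy gives a number 9.4 percentage points higher from compound 1 to compound 4 (within the scatter), so this change, unlike methyl in compound 3, does not separate from compound 1 beyond the scatter. Trifluoromethyl in place of methyl gives a number 2.7 percentage points lower from compound 3 to compound 4 (within the scatter), and 4-(trifluoromethyl)phenyl in place of 3-chlorophenyl gives a number 2.8 percentage points lower from compound 2 to compound 4 (within the scatter), so compound 4 cannot be told apart from compound 3 or compound 2. No available evidence bears on these numbers. The compounds shown leave open how an amine or a carboxylic acid on this aromatic carbon would read in this assay.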